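The source may report more compounds than this note shows. Statements on the series, on what has been measured and on what is new or still open speak of the compounds shown alone.

Within the data shown here, compound 1, with the structure `N#Cc1ccc(CNc2c(NC3CCCC3)c(=O)c2=O)cc1`, is one of three compounds measured in a functional assay for inhibition, with Rattus norvegicus as the target; on this read-out lower numbers stand for stronger inhibition and higher numbers for weaker inhibition. On that read-out compound 1 gives 9400 nM, the highest of the three numbers and therefore the weakest inhibition among them. Compound 2, with the structure `CCc1cc(Br)ccc1C/N=c1\c(O)c(O)\c1=N/C(C)(C)C`, gives 270 nM in this assay, and compound 3, with the structure `CCc1cc(C#N)ccc1C/N=c1\c(O)c(O)\c1=N/C(C)(C)CC`, gives 110 nM. Both of those values lie well apart from the number for compound 1, beyond the usual scatter of this measurement.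

Compound 4, with the structure `CN(c1c(NCc2ccc(C#N)cc2)c(=O)c1=O)C(C)(C)C`, is not yet measured. It differs from compound 1 in one place: methyl(tert-butyl)amino in place of cyclopentylamino on an aromatic carbon. Among the measured compounds shown here, no directly comparable pair among the measured compounds shows what this exchange does, so the expectation rests on the wider picture alone. Compound 2 and compound 3 carry branched groups on the corresponding nitrogen and give low numbers, but they also differ from compound 1 elsewhere. For compound 4 a step from compound 1 that stays within the scatter, a 1.6-fold lower number from compound 1 to compound 4 (0.19 log units; within the scatter), is expected. The estimate for compound 4 is 6000 nM, with a range from 1500 nM to 25000 nM.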

Compound 4, half-maximal inhibitory concentration: 18300 nM
Beside the measured number, compound 4's estimate is 3.1-fold (0.48 log units) below it; measured number inside the range.
By their numbers in this assay, from the lowest: compound 3; then compound 2; then compounds 1 and 4 (each within the scatter of the next).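

Replacing cyclopentylamino with methyl(tert-butyl)amino on the core of compound 1 gives a 1.9-fold higher number from compound 1 to compound 4 (0.29 log units; within the scatter) in this assay. Among these compounds, this is the first direct reading at this position: the ring and the hydrogen-bond donor of the cyclopentylamino group both leave, the count of heavy atoms stays the same, and the two compounds cannot be told apart in this measurement. No supporting data bear on why this exchange gives this result.

From the compounds shown here alone, the ring and the nitrogen hydrogen leave together, so their separate contributions remain open; methyl(cyclopentyl)amino on the same core would keep the ring without that hydrogen, and tert-butylamino would keep that hydrogen without the ring. Compound 2 and compound 3 differ from compound 1 in more than one place, leaving the source of their lower numbers unresolved.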